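This account rests on a few compounds, and the source may have more. Where it says the series, first, only, none or still open, it means among the compounds named here.

Measured compounds:
compound 1 `NC(=O)CC[C@H](NC(=O)CN(c1nc(Cl)nc2[nH]cnc12)C1CC1)C(=O)O` gives 33.1% in a functional assay on the whole organism (Tail, strain ICR) with Mus musculus as the target, in the tail flick test, with a stated time of 30 min, at a dose of 25 umol/kg by the oral route; a lower number here means a weaker effect, a higher number a stronger effect of the compound at the dose given;
compound 2 `O=C(CN(c1nc(Cl)nc2[nH]cnc12)C1CC1)N[C@@H](CO)C(=O)O` gives 38.7% in this assay;
compound 3 `N=C(N)NCCC[C@H](NC(=O)CN(c1nc(Cl)nc2[nH]cnc12)C1CC1)C(=O)O` gives 45.4% in this assay.

Compound 3 holds the highest of the three numbers; its nearest neighbour is compound 2, whose value lies within the scatter of it, and the gap to compound 1, a number 12.3 percentage points higher from compound 1 to compound 3 (beyond the scatter), is the only one that goes beyond the scatter.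

Compound 4 `NCCCC[C@H](NC(=O)CN(c1nc(Cl)nc2[nH]cnc12)C1CC1)C(=O)O` is not yet measured. It differs from compound 3 by a group of 2 heavy atoms (1 carbon, 1 nitrogen; no ring) in place of a group of 4 heavy atoms (1 carbon, 3 nitrogen; no ring), on a saturated chain carbon, four bonds along the chain from an amide-type nitrogen and a carbonyl carbon

All three measured steps, a number 5.6 percentage points higher from compound 1 to compound 2 (within the scatter), a number 12.3 percentage points higher from compound 1 to compound 3 (beyond the scatter) and a number 6.7 percentage points higher from compound 2 to compound 3 (within the scatter), exchange the group on the same side chain and move the read-out only modestly, two of them staying within the scatter. The change from compound 3 to compound 4 is of the same kind, so no step beyond the scatter is expected in this assay, with a slight lean downwards since compound 3 sits at the top of the set.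

For compound 4 the expected value is 40%, range 28% to 52%, that is a step of a number 5.4 percentage points lower from compound 3 to compound 4 (within the scatter), an estimate only.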

Compound 4, a percentage reported as activity, at one dose (the size of the read-out at that dose, not a potency): 31.2%
Beside the measured number, compound 4's estimate is 8.8 percentage points above it, and the stated range covers the measured number.
By their numbers in this assay, from the lowest: compounds 4, 1, 2 and 3 (each within the scatter of the next, the first and the last beyond it).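

With aminomethyl entering on a saturated chain carbon, four bonds along the chain from an amide-type nitrogen and a carbonyl carbon, this assay gives a number 14.2 percentage points lower from compound 3 to compound 4 (beyond the scatter) in this series, so the group at the end of the side chain of compound 3 cannot be exchanged here without a step beyond the scatter. The same compound stays close to the other two, with a number 7.5 percentage points lower from compound 2 to compound 4 (within the scatter) and a number 1.9 percentage points lower from compound 1 to compound 4 (within the scatter) as its steps, both within the scatter, so this side chain does not set itself apart from the hydroxy and carbamoyl-bearing ones. Nothing available gives a reason for the step from compound 3.

Open, from the compounds shown here alone, is whether a side chain ending in a carboxylic acid, or a longer chain ending in an amine, would move the read-out in the same direction. Also open, going by these compounds, is whether these gaps persist at other doses or times.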